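The source may hold more compounds than are shown below. What is called first, only, known or untested is meant among the compounds shown, and "the series" means these compounds.

Compound 1, `Nc1cccc(-c2cn3nc(-c4ccc(F)cc4)sc3n2)c1`, is tested in a functional assay on FM3A cells (Mus musculus) for inhibition, read by cell counting, with a stated time of 2 days (a higher number here means a weaker inhibitor, a lower number a stronger inhibitor), and gives 33000 nM, the highest of the two numbers available; its nearest neighbour is compound 2, `CCc1ccc(-c2nn3cc(-c4cccc(N)c4)nc3s2)cc1`, which gives 8200 nM. Among the measured compounds shown here, the only measured step, a 4.0-fold lower number from compound 1 to compound 2 (0.60 log units; beyond the scatter), changes the same aryl ring that is altered in compound 3, `Nc1cccc(-c2cn3nc(-c4cccs4)sc3n2)c1`, where the change from compound 1 is thiophen-2-yl in place of 4-fluorophenyl on an aromatic carbon. That step is modest and concerns a different kind of change, so for compound 3 only a small move in this assay is expected, a 1.3-fold lower number from compound 1 to compound 3 (0.12 log units; within the scatter), giving an estimate of 25000 nM within 8000 nM to 70000 nM.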

Compound 3, half-maximal inhibitory concentration: > 250000 nM
Compound 3 gave a limit, no number; the forecaster's own chance of this, stated with the estimate: 10%; at least 10-fold (1.00 log units) between middle value and limit.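

In this assay, this aromatic carbon proves sensitive to which ring it carries: thiophen-2-yl in place of 4-fluorophenyl gives an at least 7.5-fold higher number from compound 1 to compound 3 (0.87 log units; beyond the scatter). The earlier step, a 4.0-fold lower number from compound 1 to compound 2 (0.60 log units; beyond the scatter), exchanged only a group on the six-membered ring and went the other way. Compound 3 gives a limit and no number: the limit of > 250000 nM in this assay, at which 1 of the 3 values shown sits.

The compounds shown leave open whether the rise follows from the change of ring or from the loss of the fluoro group. An unsubstituted phenyl or a methoxyphenyl at this carbon would separate the two.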